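From 4-butoxyphenyl to 3-chlorophenyl on a shared core

The source may hold more compounds than are shown below. What is called first, only, known or untested is meant among the compounds shown, and "the series" means these compounds.

Values in a functional assay on MDA-MB-231 cells (Homo sapiens) for antiproliferative activity, read by MTT assay, with a stated time of 24 h (on this read-out higher numbers stand for weaker inhibition and lower numbers for stronger inhibition), follow.
- Compound 1 `Cc1ccccc1NNC(=O)c1cccc(NS(=O)(=O)c2cnc(O)nc2O)c1` gives > 20000 nM as a limit of the assay, not a number
- Compound 2 `CCCCOc1ccc(C(=O)NNC(=O)c2ccc(NS(=O)(=O)c3cnc(O)nc3O)cc2)cc1` gives 11900 nM as a number
- Compound 3 `CCCCOc1ccc(C(=O)NNC(=O)c2cccc(NS(=O)(=O)c3cnc(O)nc3O)c2)cc1` gives 17000 nM as a number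

Compound 3 at 17000 nM lies within the scatter of compound 2 at 11900 nM on this read-out. Compound 4 `O=C(NNC(=O)c1cccc(NS(=O)(=O)c2cnc(O)nc2O)c1)c1cccc(Cl)c1` carries 3-chlorophenyl in place of 4-butoxyphenyl on a carbonyl carbon, a swap counted as 3-chlorophenyl in place of 4-butoxyphenyl on a carbonyl carbon in full. For the measured compounds named here, no measured pair isolates this swap, so no step in this assay can be read directly, and none beyond the scatter is expected. The estimated move is a 1.1-fold lower number from compound 3 to compound 4 (0.03 log units; within the scatter) and has no firm direction. For compound 4 the estimated value is 16000 nM with an expected range from 8500 nM to 30000 nM if a number is obtained. A limit instead of a number is also possible for compound 4.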

Compound 4, half-maximal inhibitory concentration: 3180 nM
Beside the measured number, compound 4's estimate is 5.0-fold (0.70 log units) above it; the measured number lies below the stated range.
By their numbers in this assay, from the lowest: compound 4; then compounds 2 and 3 (each within the scatter of the next). At a limit, above all of these: compound 1.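

In this assay, for the compounds shown here, placing 3-chlorophenyl in place of 4-butoxyphenyl on a carbonyl carbon gives a 5.3-fold lower number from compound 3 to compound 4 (0.73 log units; beyond the scatter), the first step here beyond the scatter, so the group at this place can move the number. The second step, with (3-chlorophenyl)carbonyl in place of 2-methylphenyl on an amine nitrogen, gives an at least 6.2-fold lower number from compound 1 to compound 4 (0.79 log units; beyond the scatter). Compound 1 stands at a limit of the assay, not a number, so that step is only a minimum: the limit of > 20000 nM in this assay, at which 1 of the 4 values shown sits.

From the compounds shown here alone, whether the chlorine or the loss of the butoxy chain matters more stays open. A plain phenyl, a methoxyphenyl or an aminophenyl at this place could help separate the two.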